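The compounds below may be only part of what the source reports. "The series", "measured", "known", "first", "only" and "open" are said of these compounds alone.

Measured in a functional assay on MIA cells (Homo sapiens) for inhibition, read by MTT assay, with a stated time of 72 h; on this read-out higher numbers stand for weaker inhibition of growth and lower numbers for stronger inhibition of growth:
Compound 1, `N#C/C(=C\c1c(F)c(F)c(F)c(F)c1F)C(=O)c1c[nH]c2ccccc12`, gives 21000 nM.
Compound 2, `N#C/C(=C\c1c[nH]c2ccccc12)C(=O)c1c[nH]c2ccccc12`, gives 14000 nM.
Compound 3, `COc1ccc(CNC(=O)/C(C#N)=C/c2ccco2)cc1`, gives 34000 nM.

Among these three, the value of compound 3 lies beyond the scatter from that of compound 2, while it sits within the scatter of compound 1, so no order between compound 3 and compound 1 can be read from the numbers. Compound 4, `COc1ccc(CNC(=O)/C(C#N)=C/c2ccc(C)cc2)cc1`, has not yet been tested. It differs from compound 3 in one place: 4-methylphenyl in place of furan-2-yl on a double-bonded chain carbon bound to a double-bonded chain carbon. Among the compounds with values here, no measured pair of compounds shows such an exchange, so nothing here fixes the size of the step in this assay. The step is expected to be small, a 1.1-fold lower number from compound 3 to compound 4 (0.05 log units; within the scatter), with no change beyond the scatter in either direction. Compound 4 is therefore estimated at 30000 nM, within a range from 10000 nM to 90000 nM.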

Compound 4, concentration for 50% growth inhibition: 38000 nM
For compound 4 the middle estimate is 1.3-fold (0.10 log units) below the measured one; the measured number falls inside the stated range.
By their numbers in this assay, from the lowest: compounds 2, 1, 3 and 4 (each within the scatter of the next, the first and the last beyond it).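

In this assay, 4-methylphenyl in place of furan-2-yl at this double-bonded chain carbon gives a 1.1-fold higher number from compound 3 to compound 4 (0.05 log units; within the scatter) and so does not separate the two groups. A five-membered aromatic ring holding oxygen and a larger six-membered carbon-only ring bearing methyl therefore give numbers that cannot be told apart on this read-out. No measurement shown here offers an explanation for this result. From the compounds shown here alone, whether an amine or a carboxylic acid at this place would move the number beyond the scatter remains open. So does what plain phenyl would give.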